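Notes on compound 4, an isomer of compound 2

The compounds below may be only part of what the source reports. "The series", "measured", "known", "first", "only" and "open" are said of these compounds alone.

Measured compounds:
compound 1 `COc1ccccc1/C=c1\c(=O)[nH]/c(=C/c2cccc(Cl)c2Cl)c(=O)n1C` — 300 nM
compound 2 `C=CCn1c(=O)/c(=C\c2ccc(F)c(Br)c2)[nH]c(=O)/c1=C\c1ccccc1OC` — "not active" (no number reported)
compound 3 `C=CCn1c(=O)/c(=C\c2cc(OC)c(OC)c(OC)c2)[nH]c(=O)/c1=C\c1cccc(Br)c1` — "not active" (no number reported)

All three were run in a functional assay on BGC-823 cells (Homo sapiens) for cytotoxicity, read by CCK-8 assay, with a stated time of 72 h; a higher number here means a weaker inhibitor, a lower number a stronger inhibitor. Within the data shown here, compound 1 gives 300 nM and is the only member of the set with a number. Compound 2 gives "not active" (no number reported), so no single number stands against it. Compound 3 likewise gives "not active" (no number reported). On the numbers shown, compound 2 stands with compound 3 among the entries without a number, apart from compound 1; because no pair of measured compounds differs in a single place, no step size can be read from the set, and nothing beyond the three values themselves can be said of compound 1 against compound 2.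

The next compound is compound 4 `C=CCn1c(=O)/c(=C\c2cc(Br)ccc2F)[nH]c(=O)/c1=C\c1ccccc1OC`. Against compound 2 the change is 5-bromo-2-fluorophenyl in place of 3-bromo-4-fluorophenyl on a double-bonded chain carbon bound to an aromatic carbon. The two share the same atoms and the same core, so the expected step in this assay is none beyond the usual scatter, in no preferred direction, and the most likely outcome is again an entry without a number, as for compound 2 with "not active" (no number reported). Should a number be reported, compound 4 is estimated at 15000 nM, with a range from 2000 nM to 80000 nM.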

Compound 4, half-maximal inhibitory concentration: "not active" (no number reported)
No number was reported for compound 4; the estimate stays without a comparison.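

In this assay compound 2 gives "not active" (no number reported) and compound 4 gives "not active" (no number reported), so no step can be read between these two isomers. The compounds shown leave open how 5-bromo-2-fluorophenyl and 3-bromo-4-fluorophenyl would compare in a compound that returns a number, such as compound 1. No available evidence bears on this result.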